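Diethylamino for dimethylamino on the longer chain

The source may hold more compounds than are shown below. What is called first, only, known or untested is meant among the compounds shown, and "the series" means these compounds.

Measured in a functional assay on A549 cells (Homo sapiens) for antiproliferative activity, read by MTT assay, with a stated time of 48 h; a higher number here means a weaker inhibitor, a lower number a stronger inhibitor:
Compound 1 `CCN(CC)CCn1c(N)c(-c2nc3ccccc3n2C)c2nc(C#N)c(C#N)nc21`: > 50000 nM, a limit of the assay
Compound 2 `CN(C)CCCCn1c(N)c(-c2nc3ccccc3n2C)c2nc(C#N)c(C#N)nc21`: 6150 nM

Within the data shown here, compound 2 holds the only actual number so far, and the other value is a limit. Compound 3 `CCN(CC)CCCCn1c(N)c(-c2nc3ccccc3n2C)c2nc(C#N)c(C#N)nc21` follows from compound 2 by diethylamino in place of dimethylamino on a saturated chain carbon, four bonds along the chain from an aromatic nitrogen. Among the measured compounds shown here, the one measured step bearing on this is an at least 8.1-fold lower number from compound 1 to compound 2 (0.91 log units; beyond the scatter), which changes the chain as well. On that step, a higher number is expected in this assay, though a smaller step. The expected step is a 2.0-fold higher number from compound 2 to compound 3 (0.29 log units; within the scatter). For compound 3 the estimate is 12000 nM, with an expected range of 4000 nM to 40000 nM.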

Compound 3, half-maximal inhibitory concentration: 1720 nM
The estimate for compound 3 lay 7.0-fold (0.84 log units) above the measured number; measured number outside the range, below it.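

In this assay diethylamino in place of dimethylamino on a saturated chain carbon, four bonds along the chain from an aromatic nitrogen, gives a 3.6-fold lower number from compound 2 to compound 3 (0.55 log units; beyond the scatter) and so goes the opposite way to the estimate. Unlike the earlier step, which changed the chain as well, this one reads the amine end alone. With diethylamino held fixed, the chain separates the other pair with an at least 29-fold lower number from compound 1 to compound 3 (1.46 log units; beyond the scatter) and that step rests on a limit for compound 1: the limit of > 50000 nM in this assay, at which 1 of the 3 values shown sits.

From the compounds shown here alone, whether a pyrrolidine or morpholine at the chain end would extend the gain remains open. So does the effect of a longer chain.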